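Replacing an acid with a cyclopropyl amide on a thiazole amine

This account rests on a few compounds, and the source may have more. Where it says the series, first, only, none or still open, it means among the compounds named here.

Of the compounds shown here, two have been tested in a functional assay on CHO cells for agonist activity at Free fatty acid receptor 1 (Homo sapiens), read by a luciferase reporter; a lower number here means a smaller maximal response, a higher number a larger maximal response. Compound 1, with the structure `Cc1nc(-c2ccc(C(F)(F)F)cc2)sc1CNc1ccc(CC(=O)O)cc1`, gives 18%. Compound 2, with the structure `O=C(O)CSc1ccc(NCc2cccc(Oc3ccccc3)c2)cc1`, gives 84%. Compound 1 thus stands lowest of the two numbers, and the gap to compound 2 lies beyond the usual scatter.

Compound 3, with the structure `Cc1nc(-c2ccc(C(F)(F)F)cc2)sc1CNc1ccc([C@H]2C[C@@H]2C(N)=O)cc1`, has not yet been measured. It differs from compound 1 in one place: 2-carbamoylcyclopropyl in place of carboxymethyl on an aromatic carbon. Within the data shown here, no measured pair shows what this change does in this assay, so the expectation rests on the low position of compound 1 alone.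

With nothing to point either way, compound 3 is expected to stay near compound 1, with no step beyond the scatter, as a number 3 percentage points lower from compound 1 to compound 3 (within the scatter). Compound 3 is therefore estimated at 15%, within a range from 0% to 45%.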

Compound 3, largest response reached (reported as percent of maximum), in percent of the reference or control that the assay uses: 80%
Compound 3: middle estimate off by 65 percentage points, on the low side; measured number above the stated range.
By their numbers in this assay, from the lowest: compound 1; then compounds 3 and 2 (each within the scatter of the next).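

In this assay, putting 2-carbamoylcyclopropyl in place of carboxymethyl on the aromatic carbon para to a large group gives a number 62 percentage points higher from compound 1 to compound 3 (beyond the scatter), so the core of compound 1 can give a large maximal response once this one group is changed. Compound 3 also shows that, on this core, a carboxylic acid at this position is not needed for such a response. Nothing available explains why this swap has so large an effect.

The swap brings in a three-membered ring, an amide and 2 defined stereocentres all at once, so the step cannot be divided among them. A 2-carboxycyclopropyl group would test the ring with the acid kept, a carbamoylmethyl group would test the amide without the ring, and the mirror-image cyclopropyl form would test the stereocentres.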